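This account rests on a few compounds, and the source may have more. Where it says the series, first, only, none or still open, it means among the compounds named here.

In a functional assay on NIH3T3 cells (Mus musculus) (a higher number here means that more compound is needed for the effect, a lower number that less compound is needed), compound 1 `Cn1cncc1C(OCc1ccc(C#N)cc1-c1ccc(-c2ccccc2)cc1)c1ccc(C#N)cc1` gives < 0.1 nM, which is a limit of the assay and not a number. Within the data shown here, compound 2 `Cn1cncc1C(OCc1ccc(C#N)cc1C#CC(C)(C)C)c1ccc(C#N)cc1` gives 76.9 nM, the only actual number so far. Among the measured compounds shown here, the one measured step, an at least 760-fold higher number from compound 1 to compound 2 (2.88 log units; beyond the scatter), shows that the group on this aromatic carbon can matter greatly. Compound 3 `Cn1cncc1C(OCc1ccc(C#N)cc1CCC(C)(C)C)c1ccc(C#N)cc1` carries 3,3-dimethylbutyl in place of 3,3-dimethylbut-1-yn-1-yl (3,3-dimethylbutyl in place of 3,3-dimethylbut-1-yn-1-yl on an aromatic carbon), so the triple bond is lost. For the measured compounds named here, no measured step removes a triple bond, so the direction is uncertain. The expected change is far smaller, a 2.6-fold higher number from compound 2 to compound 3 (0.42 log units; beyond the scatter). Compound 3 is estimated at 200 nM, with an expected range of 40 nM to 900 nM.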

Compound 3, half-maximal effective concentration: 0.54 nM
The estimate for compound 3 lay 370-fold (2.57 log units) above the measured number; the whole stated range lies above it.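

Swapping 3,3-dimethylbut-1-yn-1-yl for 3,3-dimethylbutyl keeps the count of carbons and removes only the triple bond, yet the effect is large: a 140-fold lower number from compound 2 to compound 3 (2.15 log units; beyond the scatter). A group with no ring can therefore also reach a low number at this position, and compound 3 stands far closer to compound 1 than compound 2 does: an at least 5.4-fold higher number from compound 1 to compound 3 (0.73 log units; beyond the scatter). That step is only a bound, as compound 1 stands at a limit of the assay: the limit of < 0.1 nM in this assay, at which 1 of the 3 values shown sits.

As far as these compounds go, how far compound 3 truly lies from compound 1 stays open. So does the effect of a shorter chain, or of a chain ending in an amine or a carboxylic acid, at this position.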